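Ring size at the chain amine of compound 2

A few compounds are considered here, and "the series" means these few. Any claim that something is new, unique, unknown or untested is made for them only; others in the source may bear on it.

Measured compounds:
- compound 1 `CCN(CC)CCCOc1cc2ncnc(Nc3nc4ccc(C(=O)Nc5c(C)cccc5Cl)cc4s3)c2cc1OC`: 11700 nM
- compound 2 `COc1cc2c(Nc3nc4ccc(C(=O)Nc5c(C)cccc5C)cc4s3)ncnc2cc1OCCCN1CCCCC1`: > 100000 nM
- compound 3 `COc1cc2c(Nc3nc4ccc(C(=O)Nc5c(C)cc(C)cc5C)cc4s3)ncnc2cc1OCCCN1CCCCC1`: 24500 nM

In a functional assay on DLD-1 cells (Homo sapiens) for cytotoxicity, read by WST assay, with a stated time of 72 h (on this read-out higher numbers stand for weaker inhibition and lower numbers for stronger inhibition), compound 1 gives 11700 nM. For compound 2 the result is only a limit of the assay, > 100000 nM, so no number is known for it. Compound 3 gives 24500 nM, and an at least 4.0-fold lower number from compound 2 to compound 3 (0.61 log units; beyond the scatter). Compound 4 `COc1cc2c(Nc3nc4ccc(C(=O)Nc5c(C)cccc5C)cc4s3)ncnc2cc1OCCCN1CCCC1` is not yet measured. Compound 4 differs from compound 2 in one place: pyrrolidin-1-yl in place of piperidin-1-yl on a saturated chain carbon, three bonds along the chain from an oxygen on an aromatic ring. Among the compounds with values here, no measured pair shows this change, so nothing among the measured steps bears on it directly; compound 1 carries a different chain amine and a different aryl and gives no step. Without a precedent, no step beyond the scatter is expected, and the estimate is a number no higher from compound 2 to compound 4 (the limit leaves the size open). Compound 4 is therefore expected to give 100000 nM, between 40000 nM and 250000 nM, quite possibly again only a limit.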

Compound 4, half-maximal inhibitory concentration: > 100000 nM
Compound 4 ended at the assay's limit (the forecaster's own chance of this, stated with the estimate: 60%); the middle value lies on the limit itself.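

Compound 2 and compound 4 both end at a limit of the assay, so no step can be read between them: the limit of > 100000 nM in this assay, at which 2 of the 4 values shown sit.

The compounds shown leave open how pyrrolidin-1-yl and piperidin-1-yl compare on a readable value.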